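The source may hold more compounds than are shown below. What is called first, only, known or untested is meant among the compounds shown, and "the series" means these compounds.

Measured so far:
compound 1 `Nc1scc(CN2CCN(c3ccc(C(F)(F)F)cc3)CC2)c1C(=O)c1cccc(C(F)(F)F)c1` – 0%
compound 2 `Nc1scc(CN2CCN(C3CCCCCC3)CC2)c1C(=O)c1ccc(Cl)cc1` – 0%

In an assay on CHO cells for displacement of a labelled ligand from adenosine receptor A1 (Homo sapiens), read by scintillation counting, with a stated time of 120 min, tested at 10 uM (on this read-out lower numbers stand for less inhibition and higher numbers for more inhibition at the one concentration tested (going by the name of the read-out)), compound 2 stands level with compound 1 at the digits reported, the two values lying within the usual scatter of each other. Compound 3 `Nc1scc(CN2CCN(c3ccc(Cl)c(Cl)c3)CC2)c1C(=O)c1ccc(Cl)cc1` has not yet been measured. It differs from compound 2 in one place: 3,4-dichlorophenyl in place of cycloheptyl on an amine nitrogen in a ring. Among the compounds with values here, no step between two measured compounds is available here to guide the size of this change, so the expectation rests only on the fact that neither measured compound shows inhibition. Compound 3 is expected to show a step of about a number 3 percentage points higher from compound 2 to compound 3 (within the scatter), none beyond the scatter. The value of compound 3 is estimated at 3%, with a range from 0% to 20%.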

Compound 3, a percentage reported as inhibition, at one concentration (the size of the read-out at that concentration, not a potency): 1%
The estimate for compound 3 lay 2 percentage points above the measured number; the range from low to high includes it.
By their numbers in this assay, from the lowest: compounds 1, 2 and 3 (each within the scatter of the next).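

In this assay, within the data shown here, placing 3,4-dichlorophenyl in place of cycloheptyl on the amine nitrogen in a ring gives a step of a number 1 percentage points higher from compound 2 to compound 3 (within the scatter), the first direct comparison at this position. An aromatic ring carrying two chlorines and a seven-membered carbon ring therefore read alike here, so this swap alone does not bring out inhibition. Nothing available explains this reading.

Going by these compounds, whether an amine, a carboxylic acid or a longer chain on this nitrogen would give a clear reading remains open. So does whether any change to the shared core would.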